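Two Small Heteroaryl Sulfonamides Against a Cell-Growth Limit

This account rests on a few compounds, and the source may have more. Where it says the series, first, only, none or still open, it means among the compounds named here.

Compound 1 `CC1CCN(C2CCN(S(=O)(=O)c3ccc(C(C)(C)C)cc3)CC2)CC1` gives > 5000 nM, a limit of the assay, in a functional assay on DLD-1 cells (Homo sapiens) for antiproliferative activity, read by CellTiter-Glo, with a stated time of 72 h; a higher number here means a weaker inhibitor, a lower number a stronger inhibitor.
Compound 2 `Cc1noc(C)c1S(=O)(=O)N1CCC(N2CCC(C)CC2)CC1` gives > 5000 nM, also a limit.
Compound 3 `CC1CCN(C2CCN(S(=O)(=O)c3cccc(-c4ccc(F)cc4)c3)CC2)CC1` gives 12 nM.

Compound 2 thus stands at the limit of this assay, where (the limit of > 5000 nM in this assay, at which 2 of the 3 values shown sit). Only compound 3 returns a number, and that number is far from the limit. Compound 4 `Cc1nc(Cl)sc1S(=O)(=O)N1CCC(N2CCC(C)CC2)CC1` differs from compound 2 in one place: 2-chloro-4-methyl-1,3-thiazol-5-yl in place of 3,5-dimethyl-1,2-oxazol-4-yl on a sulfonyl sulfur. Going by the values given here, both groups are five-membered aromatic rings with 2 hetero atoms, and no measured step between two such groups exists here. With compound 2 sitting at the limit, the expected step is a number no higher from compound 2 to compound 4 (the limit leaves the size open), which is not expected to carry compound 4 into the measurable range. Compound 4 is therefore estimated at about 5000 nM, within 1500 nM to 15000 nM, most likely reported again as a limit.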

Compound 4, half-maximal inhibitory concentration: 1.6 nM
Compound 4: middle estimate off by 3100-fold (3.49 log units), on the high side; the whole stated range lies above it.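

In this assay, the place on the sulfonyl sulfur proves highly sensitive to the choice of five-membered aromatic ring with 2 hetero atoms, a step of an at least 3100-fold lower number from compound 2 to compound 4 (3.49 log units; beyond the scatter). The two groups match in heavy atoms, hydrogen-bond donors and acceptors, so those counts do not separate them. The true size of the step stays open, and the printed size is only a bound: the limit of > 5000 nM in this assay, at which 2 of the 4 values shown sit.

Which part of the entering group carries the step, the chlorine, the ring sulfur or the ring as a whole, remains open. How a 1,3-thiazol-5-yl ring with an amine in place of the chlorine would read is also unknown.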